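The source may report more compounds than this note shows. Statements on the series, on what has been measured and on what is new or still open speak of the compounds shown alone.

Measured in a functional assay on HEK293 cells with D(4) dopamine receptor (Homo sapiens) as the target, read by FLIPR; on this read-out lower numbers stand for an effect already at smaller amounts and higher numbers for an effect only at larger amounts of compound:
compound 1 `Cc1ccccc1/C(CCN1CCN(c2ccccn2)CC1)=N/O`, 4.2 nM
compound 2 `O/N=C(\CCN1CCN(c2ccccn2)CC1)c1ccc(Cl)cc1`, 475 nM
compound 3 `CO/N=C(\CCN1CCN(c2ccccn2)CC1)c1ccccc1C`, 74 nM

Compound 2 and compound 3 each differ from compound 1 in one place. The change 4-chlorophenyl in place of 2-methylphenyl on a carbon with a double bond to nitrogen brings a 110-fold higher number from compound 1 to compound 2 (2.05 log units; beyond the scatter). From compound 1 to compound 3 the step is an 18-fold higher number from compound 1 to compound 3 (1.25 log units; beyond the scatter). Compound 3 stands second highest of the three numbers.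

Compound 4 `CO/N=C(\CCN1CCN(c2ccccn2)CC1)c1ccc(Cl)cc1` awaits measurement in this assay. It arises from compound 3 by 4-chlorophenyl in place of 2-methylphenyl on a carbon with a double bond to nitrogen, the same change as from compound 1 to compound 2, now made on a core that differs from the core of compound 1 by methyl in place of hydrogen on an oxygen. For the measured compounds named here, because the only measured example of this change is a 110-fold higher number from compound 1 to compound 2 (2.05 log units; beyond the scatter), a step in the same direction and of roughly comparable size is expected from compound 3 to compound 4, a 68-fold higher number from compound 3 to compound 4 (1.83 log units; beyond the scatter), though it rests on a single pair. Compound 4 is therefore estimated at about 5000 nM in this assay, expected between 1500 nM and 20000 nM.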

Compound 4, half-maximal effective concentration: 37.6 nM
Estimate against measurement, compound 4: 130-fold (2.12 log units) above; measured number outside the range, below it.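

With methyl on the oxygen, 4-chlorophenyl in place of 2-methylphenyl gives a 2.0-fold lower number from compound 3 to compound 4 (0.29 log units; within the scatter) in this assay, so the large step on the core of compound 1 does not carry over: the same change on two cores in this assay, a 110-fold higher number (2.05 log units; beyond the scatter) from compound 1 to compound 2 and a 2.0-fold lower number (0.29 log units; within the scatter) from compound 3 to compound 4, 220-fold (2.35 log units) apart, beyond the scatter of two such steps

Methyl in place of hydrogen on the oxygen likewise depends on the group it is paired with, giving a 13-fold lower number from compound 2 to compound 4 (1.10 log units; beyond the scatter) against the earlier rise: the same change on two cores in this assay, an 18-fold higher number (1.25 log units; beyond the scatter) from compound 1 to compound 3 and a 13-fold lower number (1.10 log units; beyond the scatter) from compound 2 to compound 4, 220-fold (2.35 log units) apart, beyond the scatter of two such steps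

With one pair per core, this shows that the two changes do not add up here, but it does not show why, nor how other groups would behave.

Still open, on these data alone, is whether a longer chain on the oxygen, such as ethyl, follows the methyl result. Also open, as far as these compounds go, is where an unsubstituted phenyl on the carbon with a double bond to nitrogen would fall on each core.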